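Dimethylamino terminus on the propyl side chain

The source may report more compounds than this note shows. Statements on the series, on what has been measured and on what is new or still open speak of the compounds shown alone.

The series keeps the core of compound 1 `CC(C)(C)c1cc(C2SCC(=O)N2CCCN)cc(C(C)(C)C)c1O` and varies the chain that leaves the amide-type nitrogen of the ring. In a functional assay on aorta for inhibition of Voltage-dependent L-type calcium channel subunit alpha-1C (Rattus norvegicus) (a lower number here means a stronger inhibitor, a higher number a weaker inhibitor), compound 1 gives 4400 nM. Compound 2 `CN(C)CCN(C)CCCN1C(=O)CSC1c1cc(C(C)(C)C)c(O)c(C(C)(C)C)c1` carries the longer diamine chain and gives 1700 nM; compound 3 `CC(C)(C)c1cc(C2SCC(=O)N2CCCN2CCC(Cc3ccccc3)CC2)cc(C(C)(C)C)c1O` gives 210 nM. On these three numbers compound 2 stands second highest, nearest to compound 1 and furthest from compound 3.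

Compound 4 `CN(C)CCCN1C(=O)CSC1c1cc(C(C)(C)C)c(O)c(C(C)(C)C)c1` is not yet measured. It differs from compound 2 by hydrogen in place of (dimethylamino)methyl on a saturated chain carbon bound to an amine nitrogen, so the chain ends in dimethylamino rather than in the longer diamine.

For the measured compounds named here, the one step that bears on this is a 2.6-fold lower number from compound 1 to compound 2 (0.41 log units; beyond the scatter), where the primary amine of compound 1 was replaced by the full diamine chain. Compound 4 sits between these two ends: it keeps a tertiary amine on the chain but loses the second basic nitrogen. The expectation is therefore a number somewhere between compound 1 and compound 2, with at most a modest rise from compound 2, and possibly no step beyond the scatter, giving the expected step of a 1.5-fold higher number from compound 2 to compound 4 (0.18 log units; within the scatter).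

Compound 4 is estimated at 2600 nM, with a range from 1200 nM to 5500 nM.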

Compound 4, half-maximal inhibitory concentration: 1500 nM
For compound 4 the middle estimate is 1.7-fold (0.24 log units) above the measured one, and the stated range covers the measured number.
By their numbers in this assay, from the lowest: compound 3; then compounds 4 and 2 (each within the scatter of the next); then compound 1.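

In this assay, the step that removes (dimethylamino)methyl, a 1.1-fold lower number from compound 2 to compound 4 (0.05 log units; within the scatter), shows that the longer diamine chain of compound 2 is not needed to hold the number at this position, since the two compounds cannot be told apart. The step from the primary amine (a 2.9-fold lower number from compound 1 to compound 4 (0.47 log units; beyond the scatter)) is therefore reached with dimethylamino alone, so the earlier step (a 2.6-fold lower number from compound 1 to compound 2 (0.41 log units; beyond the scatter)) needs no more than this terminus on the propyl chain, and the extra chain length adds nothing that can be read here. No measured evidence on hand accounts for either step.

Still open, on these data alone, is how the terminus itself governs the number: a methylamino end would show whether a single methyl on the nitrogen already gives the step seen with dimethylamino, and a diethylamino end would show whether larger alkyl groups on that nitrogen move it further. A longer chain, such as butyl in place of propyl with the dimethylamino end kept, would test whether the distance from the amide-type nitrogen in the ring matters at all.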